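A Halogen Moves Round the Ring: Compound 3 to Compound 4

The source may report more compounds than this note shows. Statements on the series, on what has been measured and on what is new or still open speak of the compounds shown alone.

Measured compounds:
compound 1 `COc1ccccc1Nc1nc(-c2cccc(F)c2)nc2ccc(F)cc12`: > 50000 nM
compound 2 `Fc1cccc(-c2nc(Nc3ccccc3F)c3cc(F)ccc3n2)c1`: > 50000 nM
compound 3 `Fc1cccc(-c2nc(Nc3ccc(Cl)cc3)c3cc(F)ccc3n2)c1`: 32700 nM

In a functional assay on U-937 cells (Homo sapiens) for cytotoxicity, read by MTT assay, with a stated time of 48 h (a lower number here means a stronger inhibitor, a higher number a weaker inhibitor), compound 3 gives 32700 nM and is the only one of the three with an actual number. Compound 1 reaches only a limit, > 50000 nM, not a number. The same holds for compound 2, whose value > 50000 nM is also a limit, as summed up by the limit of > 50000 nM in this assay, at which 2 of the 3 values shown sit. The step of an at least 1.5-fold lower number from compound 1 to compound 3 (0.18 log units; that floor lies within the scatter) and the step of an at least 1.5-fold lower number from compound 2 to compound 3 (0.18 log units; that floor lies within the scatter) therefore give only floors, and the step that the two limits leave unreadable from compound 1 to compound 2 cannot be read at all.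

Compound 4 `Fc1cccc(-c2nc(Nc3cccc(Br)c3)c3cc(F)ccc3n2)c1` differs from compound 3 by 3-bromophenyl in place of 4-chlorophenyl on a nitrogen on an aromatic ring. For the measured compounds named here, no measured pair changes one halogenated phenyl for another, so nothing here points to a step beyond the scatter in this assay. Compound 4 is expected to sit close to compound 3, with an estimated step of a 1.1-fold higher number from compound 3 to compound 4 (0.03 log units; within the scatter). The estimate for compound 4 is 35000 nM, in a range from 12000 nM to 100000 nM.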

Compound 4, half-maximal inhibitory concentration: > 50000 nM
Compound 4 was reported as a limit; the forecaster's own chance of this, stated with the estimate: 40%; middle value at least 1.4-fold (0.15 log units) from the limit.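

Setting 3-bromophenyl in place of 4-chlorophenyl on the nitrogen gives an at least 1.5-fold higher number from compound 3 to compound 4 (0.18 log units; that floor lies within the scatter), so the change leaves the only measured number in the series unmatched, and the true size of the step stays unknown. The result for compound 4 in this assay is a limit, not a number, and the steps to compound 4 from compound 1 and from compound 2 cannot be read, as each joins two limits. This position has now taken four different aryl groups, yet only the 4-chlorophenyl of compound 3 gives a number: the limit of > 50000 nM in this assay, at which 3 of the 4 values shown sit.

Compound 4 changes both the halogen and its place on the ring at once, and the compounds shown do not separate the two. Also open, as far as these compounds go, is how an amine or a carboxylic acid on this phenyl ring would read in this assay.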